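Returning the Hydrazone Aryl Group to a Single Ring

The source may hold more compounds than are shown below. What is called first, only, known or untested is meant among the compounds shown, and "the series" means these compounds.

Compound 2 `CN(C)CCn1cnnc1-c1cc(Oc2ccc(NC(=O)N/N=C/c3c(O)ccc4ccccc34)cc2F)ccn1` stands lowest of the two numbers measured in a functional assay on NCI-H460 cells (Homo sapiens) for cytotoxicity, read by MTT assay, with a stated time of 72 h; on this read-out higher numbers stand for weaker inhibition and lower numbers for stronger inhibition. In this assay compound 2 gives 890 nM, while compound 1 `CN(C)CCn1cnnc1-c1cc(Oc2ccc(NC(=O)N/N=C/c3ccc(O)c(F)c3)cc2F)ccn1` gives 2620 nM. Among the compounds with values here, the one measured step, a 2.9-fold lower number from compound 1 to compound 2 (0.47 log units; beyond the scatter), is a modest move that lies beyond the scatter. Compound 3 `COc1cc(/C=N/NC(=O)Nc2ccc(Oc3ccnc(-c4nncn4CCN(C)C)c3)c(F)c2)ccc1O` has not been measured; it differs from compound 2 by 4-hydroxy-3-methoxyphenyl in place of 2-hydroxynaphthalen-1-yl on a carbon with a double bond to nitrogen. This change returns a single six-membered ring to the position on a carbon with a double bond to nitrogen, so the measured step bears on it in reverse and a number nearer to that of compound 1 seems likely. For compound 3 the estimated step is a 2.5-fold higher number from compound 2 to compound 3 (0.39 log units; beyond the scatter), upward. Compound 3 is therefore expected to give about 2200 nM in this assay, within a range from 900 nM to 5500 nM.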

Compound 3, half-maximal inhibitory concentration: 57 nM
The estimate for compound 3 lay 39-fold (1.59 log units) above the measured number, outside the stated range (below it).
By their numbers in this assay, from the lowest: compound 3; then compound 2; then compound 1.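

Going back to a single ring on the carbon with a double bond to nitrogen does not by itself raise the number in this assay: the change to 4-hydroxy-3-methoxyphenyl gives a 16-fold lower number from compound 2 to compound 3 (1.19 log units; beyond the scatter), so the two rings of 2-hydroxynaphthalen-1-yl are not needed for a low number here. What separates the two single-ring compounds is one substituent, since methoxy in place of fluoro on an aromatic carbon gives a 46-fold lower number from compound 1 to compound 3 (1.66 log units; beyond the scatter), a far larger move than the modest 2.9-fold lower number from compound 1 to compound 2 (0.47 log units; beyond the scatter) seen earlier. Nothing at hand accounts for why this exchange has so large an effect.

From the compounds shown here alone, whether methoxy is special remains open, and an ethoxy or a chloro group in its place would test that. All three compounds also carry a hydroxy group on this aryl group, so a 3-methoxyphenyl group would show whether that hydroxy group is needed.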